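Swapping a fluoro-methoxy aryl for dichlorophenyl: cytotoxicity outlook

This account rests on a few compounds, and the source may have more. Where it says the series, first, only, none or still open, it means among the compounds named here.

Measured so far in an ADME assay on BJ cells (Homo sapiens) for cytotoxicity, with a stated time of 72 h; a lower number here means that less compound is needed, a higher number that more compound is needed for the effect:
- compound 1, `C=C[C@@](C)(/C=C/c1ccc(O)c(/C=C/c2ccc(Cl)c(Cl)c2)c1)CCC=C(C)C`: > 13000 nM
- compound 2, `C=C[C@@](C)(/C=C/c1ccc(Nc2ccc(OC)c(OC)c2)cc1)CCC=C(C)C`: > 36600 nM
- compound 3, `C=C[C@@](C)(/C=C/c1ccc(Nc2ccc(OC)c(F)c2)cc1)CCC=C(C)C`: > 36600 nM

Each of these three values is a limit of this assay rather than a measured number. Compound 1 sits at the limit of > 13000 nM in this assay, at which 1 of the 3 values shown sits. Compound 2 and compound 3 both sit at the limit of > 36600 nM in this assay, at which 2 of the 3 values shown sit. Compound 3 therefore stands among the two compounds for which this assay reports only its upper limit, and no order among the three can be read.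

Among the measured compounds shown here, the only step between two measured compounds that differ in one place, a step that the two limits leave unreadable from compound 2 to compound 3, is unreadable because both ends are limits.

Compound 4, `C=C[C@@](C)(/C=C/c1ccc(Nc2ccc(Cl)c(Cl)c2)cc1)CCC=C(C)C`, arises from compound 3 by 3,4-dichlorophenyl in place of 3-fluoro-4-methoxyphenyl on a nitrogen on an aromatic ring. For the measured compounds named here, no measured step bears on this change directly. A 3,4-dichlorophenyl group also appears in compound 1, whose value is a limit, so nothing in the data points to a reading beyond the limit in either direction. The expected change, a step that the limit leaves unreadable from compound 3 to compound 4, is therefore none beyond the scatter, and compound 4 is expected to fall at 40000 nM, with a range of 15000 nM to 120000 nM and most likely to be reported as a limit again.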

Compound 4, half-maximal effective concentration: > 36600 nM
Compound 4: a limit, no number (the forecaster's own chance of this, stated with the estimate: 75%); the middle value lies beyond the limit too.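

In this assay compound 4 gives > 36600 nM, which is a limit of the assay and not a number. Compound 3 also stands at a limit, and no step can be read from compound 3 to compound 4. The compounds shown leave open whether 3,4-dichlorophenyl in place of 3-fluoro-4-methoxyphenyl changes the concentration needed for the effect.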